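Working notes: from compound 2 to compound 3

This account rests on a few compounds, and the source may have more. Where it says the series, first, only, none or still open, it means among the compounds named here.

Measured in a functional assay on HT-1080 cells (Homo sapiens) for cytotoxicity, read by MTT assay, with a stated time of 72 h; a lower number here means a stronger inhibitor, a higher number a weaker inhibitor:
- compound 1 `COc1ccc(/C=C2\CCC/C(=C\c3cccc(Br)c3)C2=O)cc1OC`: 5200 nM
- compound 2 `COc1ccc(/C=C2\CCC/C(=C\c3cc(Cl)cc(Cl)c3)C2=O)cc1OC`: 3000 nM

Only these two compounds have been measured, and compound 2 stands level with compound 1 on these numbers: the step is a 1.7-fold lower number from compound 1 to compound 2 (0.24 log units; within the scatter). Compound 3 `COc1ccc(/C=C2\CCC/C(=C\c3ccc(O)c(Cl)c3)C2=O)cc1OC` keeps the core of compound 2 and changes one group on a double-bonded chain carbon bound to a double-bonded ring carbon: 3-chloro-4-hydroxyphenyl in place of 3,5-dichlorophenyl on a double-bonded chain carbon bound to a double-bonded ring carbon. In words, 3-chloro-4-hydroxyphenyl comes in place of 3,5-dichlorophenyl.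

Going by the values given here, the only measured step at this place is a 1.7-fold lower number from compound 1 to compound 2 (0.24 log units; within the scatter). It exchanged one halogen-bearing group for another and gave no shift that can be told from scatter. Among the compounds with values here, no measured compound carries the 3-chloro-4-hydroxyphenyl group, so that step is weak guidance and the range is kept wide. No clear direction is expected in this assay. The expected change is a 1.2-fold lower number from compound 2 to compound 3 (0.08 log units; within the scatter), which is no step beyond the scatter. In this assay the estimated value for compound 3 is 2500 nM, with an expected range from 800 nM to 7000 nM.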

Compound 3, half-maximal inhibitory concentration: 7600 nM
For compound 3 the middle estimate is 3.0-fold (0.48 log units) below the measured one; measured number above the stated range.
By their numbers in this assay, from the lowest: compounds 2, 1 and 3 (each within the scatter of the next, the first and the last beyond it).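

In this assay, the position on a double-bonded chain carbon bound to a double-bonded ring carbon now gives its first step beyond the scatter: 3-chloro-4-hydroxyphenyl in place of 3,5-dichlorophenyl gives a 2.5-fold higher number from compound 2 to compound 3 (0.40 log units; beyond the scatter). This position is therefore not wholly indifferent to the aryl group it carries, although the step is modest and depends on the group it is compared with: 3-chloro-4-hydroxyphenyl in place of 3-bromophenyl gives a 1.5-fold higher number from compound 1 to compound 3 (0.16 log units; within the scatter), which cannot be told from scatter. Nothing available on the properties of these compounds accounts for the step beyond the scatter.

The exchange that gives this step alters the hydroxyl and the chlorine substitution together, so the compounds shown do not separate the part played by the hydroxyl group from that of the lost chlorine, and a phenyl group carrying a hydroxyl group alone, or a single chlorine alone, would bear on that question. Also open is how this position responds to groups of a different kind on the ring, such as an amine or a carboxylic acid, since every group shown here is a halogen-bearing phenyl.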